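Methyl Ester Versus Free Acid at One Concentration

The source may report more compounds than this note shows. Statements on the series, on what has been measured and on what is new or still open speak of the compounds shown alone.

compound 1, `COC(=O)c1cc(-n2cc(-c3cc(OC)cc(OC)c3)nn2)ccc1O`, 3%
compound 2, `COc1cc(OC)cc(-c2cn(-c3ccc(O)c(C(=O)O)c3)nn2)c1`, 2%
compound 3, `COc1ccccc1-c1cn(-c2ccc(O)c(C(=O)O)c2)nn1`, 4%

Of the compounds shown here, three have been tested so far in a functional assay on HCT-116 cells (Homo sapiens) for inhibition, read by MTT assay, with a stated time of 2 days, tested at 10 uM; a higher number here means more inhibition at the concentration tested (going by the name of the read-out), a lower number less inhibition. In this assay compound 1 gives 3%, compound 2 gives 2% and compound 3 gives 4%. All three numbers lie close together, and none of them stands out from the others by more than the usual scatter of such a measurement; in plain terms, none of the three does much at the concentration used.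

Compound 1 and compound 2 differ in one place only: methyl in place of hydrogen on an oxygen next to a carbonyl group. This change moves the read-out by a number 1 percentage points higher from compound 2 to compound 1 (within the scatter).

Compound 4, `COC(=O)c1cc(-n2cc(-c3ccccc3OC)nn2)ccc1O`, has not yet been measured. It is made from compound 3 by the very same kind of change, (methyl in place of hydrogen on an oxygen next to a carbonyl group), at the same place. How the core of compound 3 differs from the core of compound 2 is not broken down here, so compound 3 and compound 4 rest on a different core than compound 1 and compound 2, but the change itself is identical in both pairs.

Because the earlier step, a number 1 percentage points higher from compound 2 to compound 1 (within the scatter), was within the scatter, the step for compound 4 is expected to be no change at the digits printed from compound 3 to compound 4 (within the scatter). On that basis compound 4 is estimated to give 4% in this assay, most likely between -3% and 12%.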

Compound 4, a percentage reported as inhibition, at one concentration (the size of the read-out at that concentration, not a potency): 8%
Compound 4: middle estimate off by 4 percentage points, on the low side; measured number inside the range.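

In this assay, replacing hydrogen with methyl on an oxygen next to a carbonyl group, which turns carboxy into methoxycarbonyl, gives a number 4 percentage points higher from compound 3 to compound 4 (within the scatter) on the core of compound 3. Set beside the same change on the core of compound 1, the new step does not differ from the earlier one: the same change on two cores in this assay, a number 1 percentage points higher (within the scatter) from compound 2 to compound 1 and a number 4 percentage points higher (within the scatter) from compound 3 to compound 4, 3 percentage points apart, within the scatter of two such steps. This shows that the change carries from one core to the other in a limited sense: on neither core does it give a step that stands clear of the scatter, but it does not show that methoxycarbonyl truly raises inhibition over carboxy, and these two pairs, all with little inhibition at the concentration tested, cannot say how the change would behave on a core that gives a large read-out.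

The compounds shown leave open whether another group in that place, such as an amide or a longer ester chain like ethoxycarbonyl, would give a read-out clearly apart from these. Also open, from the compounds shown here alone, is how these four compounds would read at another concentration, since a single concentration gives no potency.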